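Amide variation on a dimethoxy core under paw edema inhibition

The compounds below may be only part of what the source reports. "The series", "measured", "known", "first", "only" and "open" are said of these compounds alone.

Compound 2 `CCCCCNC(=O)CC1CCc2cc(OC)c(OC)cc21` is one of two measured amides on the shared core. In a functional assay on the whole organism (strain Wistar) for inhibition, with Rattus norvegicus as the target, read by paw edema, with stated times of 60 min and 3 h, at a dose of 100 mg/kg by the oral route (on this read-out higher numbers stand for more inhibition at the one dose given (going by the name of the read-out) and lower numbers for less inhibition), compound 2 gives 37.7%, and compound 1 `COc1cc2c(cc1OC)C(CC(=O)N(C)C)CC2` gives 34.8%, the two within the scatter of each other. For the measured compounds named here, the only measured step, a number 2.9 percentage points higher from compound 1 to compound 2 (within the scatter), is the one that bears on what follows. Compound 3 `COc1cc2c(cc1OC)C(CC(=O)N1CCCCC1)CC2` carries piperidin-1-yl in place of pentylamino on a carbonyl carbon. Because that earlier step a number 2.9 percentage points higher from compound 1 to compound 2 (within the scatter) stayed within the scatter, no change beyond the scatter is expected in this assay, and the expected step is a number 1.7 percentage points lower from compound 2 to compound 3 (within the scatter). Compound 3 is estimated at 36%, within 26% to 46%.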

Compound 3, a percentage reported as inhibition, in the whole organism at one dose (the size of the read-out at that dose, not a potency): 31.9%
For compound 3 the middle estimate is 4.1 percentage points above the measured one; the range from low to high includes it.
By their numbers in this assay, from the lowest: compounds 3, 1 and 2 (each within the scatter of the next).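

Setting piperidin-1-yl on the carbonyl carbon gives a step of a number 5.8 percentage points lower from compound 2 to compound 3 (within the scatter), and the step against dimethylamino is a number 2.9 percentage points lower from compound 1 to compound 3 (within the scatter), so in this assay this change stays within the scatter from both earlier amides. At this place, the ring and the loss of the hydrogen-bond donor carried by pentylamino therefore bring no readable change at the one dose given. No supporting measurement bears on this result.

Going by these compounds, whether morpholin-4-yl, benzylamino or a carboxylic acid at this place would move the number beyond the scatter remains open.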